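The source may hold more compounds than are shown below. What is called first, only, known or untested is meant among the compounds shown, and "the series" means these compounds.

Measured compounds: compound 2, `NCc1ccc2oc(=O)c(C(=O)Oc3ccccc3)cc2c1`, gives 85.5%; compound 1, `CC(C)(C)C(=O)OCc1ccc2oc(=O)c(C(=O)Oc3cccc(Br)c3)cc2c1`, gives 48.2%.

In a functional assay on HT-1080 cells (Homo sapiens), read by transwell migration, with a stated time of 24 h, tested at 1 uM (a lower number here means a stronger effect, a higher number a weaker effect of the compound at the concentration tested), compound 2 stands highest of the two numbers shown, with compound 1 lower by a gap beyond the scatter; the two compounds differ in more than one place, so those values show only the gap itself. Compound 3, `NCc1ccc2oc(=O)c(C(=O)Oc3cccc(Br)c3)cc2c1`, differs from compound 2 by bromo in place of hydrogen on an aromatic carbon. Among the compounds with values here, no step of this kind is on record among the measured compounds, so compound 3 is expected to show a modest downward step of a number 15.5 percentage points lower from compound 2 to compound 3 (beyond the scatter) in this assay, an estimate with wide uncertainty. Compound 3 is thus estimated at 70%, within 45% to 95%.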

Compound 3, a percentage reported as activity, at one concentration (the size of the read-out at that concentration, not a potency): 79.3%
Estimate against measurement, compound 3: 9.3 percentage points below, within the range that was stated.
By their numbers in this assay, from the lowest: compound 1; then compounds 3 and 2 (each within the scatter of the next).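

In this assay, the step is a number 6.2 percentage points lower from compound 2 to compound 3 (within the scatter), so bromo in place of hydrogen on this aromatic carbon, phenyl to 3-bromophenyl, gives no change that can be told from the scatter. The change on the saturated chain carbon, amino in place of ((tert-butyl)carbonyl)oxy, is much larger, with a number 31.1 percentage points higher from compound 1 to compound 3 (beyond the scatter) on the same 3-bromophenyl ester. No measurement on record gives a cause for either step.

On these data alone, it remains open whether chloro or methoxy on this aromatic carbon would behave as bromo does. As far as these compounds go, a carboxylic acid or a longer chain in place of the amino also remains open.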